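The source may hold more compounds than are shown below. What is called first, only, known or untested is meant among the compounds shown, and "the series" means these compounds.

Measured compounds:
compound 1 `Cc1cc(O)c(C2=NN(c3ccc(S(N)(=O)=O)cc3)C(c3ccccc3O)C2)cc1Cl`: 1460 nM
compound 2 `Cc1cc(O)c(C2=NN(c3ccc(S(N)(=O)=O)cc3)C(/C=C/c3ccccc3)C2)cc1Cl`: 2360 nM

Of the compounds shown here, two have been measured in a functional assay on HOP-92 cells (Homo sapiens) for antiproliferative activity, with a stated time of 48 h; a lower number here means a stronger inhibitor of growth, a higher number a weaker inhibitor of growth. Compound 1 gives 1460 nM, and compound 2 gives 2360 nM. Among the compounds with values here, the one step between them, a 1.6-fold higher number from compound 1 to compound 2 (0.21 log units; within the scatter), is within the scatter, so the two numbers cannot be set in order; compound 2 simply stands at the same level as compound 1 within the noise of the assay.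

Compound 3 `COc1ccc(C2CC(c3cc(Cl)c(C)cc3O)=NN2c2ccc(S(N)(=O)=O)cc2)cc1OC` has not yet been measured in this assay. It differs from compound 2 in one place: 3,4-dimethoxyphenyl in place of 2-phenylethenyl on a saturated ring carbon. Within the data shown here, the only measured step that bears on this change is the one at the same saturated ring carbon, a 1.6-fold higher number from compound 1 to compound 2 (0.21 log units; within the scatter), where exchanging one group on that carbon for another moved the number by less than the scatter. On that single precedent, the step from compound 2 to compound 3 is expected to stay within the scatter as well, in no firm direction, as a 1.2-fold lower number from compound 2 to compound 3 (0.09 log units; within the scatter). Compound 3 is therefore estimated at 1900 nM in this assay, with a range from 750 nM to 4800 nM.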

Compound 3, concentration for 50% growth inhibition: 1810 nM
Compound 3: middle estimate off by 1.0-fold (0.02 log units), on the high side, within the range that was stated.
By their numbers in this assay, from the lowest: compounds 1, 3 and 2 (each within the scatter of the next).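

In this assay, the saturated ring carbon next to the ring nitrogen now carries a third group, 3,4-dimethoxyphenyl, and the number stays within the scatter of both earlier compounds: replacing 2-phenylethenyl gives a 1.3-fold lower number from compound 2 to compound 3 (0.12 log units; within the scatter), and replacing 2-hydroxyphenyl gives a 1.2-fold higher number from compound 1 to compound 3 (0.09 log units; within the scatter). Unlike the earlier pair, the step from 2-phenylethenyl brings in 10 heavy atoms in place of 8, 2 hydrogen-bond acceptors in place of 0, and no double bond outside aromatic rings, yet these differences do not separate the two compounds in this read-out. The three compounds therefore stand at one level within the noise of the assay, and no supporting data are available to account for this.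

Going by these compounds, how an amine, a carboxylic acid or a longer alkyl chain on this carbon would read remains open, so it is still unknown whether any group here can move the number beyond the scatter. Also open, on these data alone, is what happens when the 4-sulfamoylphenyl or the 5-chloro-2-hydroxy-4-methylphenyl group is exchanged, as both stay the same across all three compounds.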